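The compounds below may be only part of what the source reports. "The series", "measured", "known", "first", "only" and "open" are said of these compounds alone.

Series values in an ADME assay on CCRF-CEM cells (Homo sapiens) for cytotoxicity, with a stated time of 5 days; a lower number here means a stronger inhibitor, a higher number a weaker inhibitor:

- compound 1 `C=CCNc1ncnc2c1ncn2[C@H]1C[C@H](N=[N+]=[N-])[C@@H](CO)O1`: > 100000 nM (a limit)
- compound 2 `C=CCNc1nc(N)nc2c1ncn2[C@H]1C[C@H](N=[N+]=[N-])[C@@H](CO)O1`: > 100000 nM (a limit)

Compound 2 stands only at a limit, > 100000 nM, so it has no numerical value. Both measured compounds share this position: the limit of > 100000 nM in this assay, at which 2 of the 2 values shown sit. Among the measured compounds shown here, the single measured step, a step that the two limits leave unreadable from compound 1 to compound 2, gives no size to carry forward, and it concerns a different place on the core.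

Compound 3 `[N-]=[N+]=N[C@H]1C[C@H](n2cnc3c(NCCO)nc(N)nc32)O[C@@H]1CO` follows from compound 2 by one change: hydroxymethyl in place of vinyl on a saturated chain carbon bound to a nitrogen on an aromatic ring. In words, this is hydroxymethyl in place of vinyl on a saturated chain carbon bound to a nitrogen on an aromatic ring. For the measured compounds named here, no measured step covers this change, so no shift beyond the scatter is expected in this assay. The expected step is a number no higher from compound 2 to compound 3 (the limit leaves the size open), with no direction predicted. For compound 3 the estimated value is 100000 nM, with an expected range of 40000 nM to 200000 nM, and a reported limit is the likeliest outcome.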

Compound 3, half-maximal inhibitory concentration: > 100000 nM
Compound 3: no number, only a limit; the forecaster's own chance of this, stated with the estimate: 85%; the middle value lies on the limit itself.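

No step can be read from compound 2 to compound 3 in this assay, since each stands only at a limit, and the change from allylamino to (2-hydroxyethyl)amino therefore has no size. The compounds shown leave open whether any change on the shared core gives a readable number in this assay: the limit of > 100000 nM in this assay, at which 3 of the 3 values shown sit.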